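The compounds below may be only part of what the source reports. "The series", "measured", "known", "first", "only" and "open" are said of these compounds alone.

In an ADME assay on MT4 cells (Homo sapiens) for cytotoxicity, read by spectrophotometry, with a stated time of 5 days (a lower number here means that less compound is tolerated, a higher number that more compound is tolerated), compound 1 (`Cc1ccc2c(c1)/C(=N/NC(=S)NO)C(=O)N2CN(C)C`) gives 651000 nM and compound 2 (`CN(C)CN1C(=O)/C(=N\NC(=S)NO)c2cc(F)ccc21`) gives 599000 nM while compound 3 (`CCN(CC)CN1C(=O)/C(=N\NC(=S)NO)c2cc(Cl)ccc21`) gives 562000 nM and so stands within the scatter of both. Compound 4 (`CN(C)CN1C(=O)/C(=N\NC(=S)NO)c2cc(Cl)ccc21`) follows from compound 3 by dimethylamino in place of diethylamino on a saturated chain carbon bound to an amide-type nitrogen in a ring with dimethylamino in place of diethylamino on a saturated chain carbon bound to an amide-type nitrogen in a ring. Going by the values given here, no measured step makes this exchange. Among the compounds with values here, the one measured step, a 1.1-fold lower number from compound 1 to compound 2 (0.04 log units; within the scatter) for fluoro in place of methyl on an aromatic carbon, lies elsewhere on the structure. Compound 1 and compound 2 carry dimethylamino, and their values lie within the scatter of compound 3. No step beyond the scatter is expected in this assay here. The estimated step is a 1.0-fold higher number from compound 3 to compound 4 (0.02 log units; within the scatter) (expected). Compound 4 is estimated at 590000 nM (expected range 400000 nM to 870000 nM).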

Compound 4, half-maximal cytotoxic concentration: 610000 nM
Beside the measured number, compound 4's estimate is 1.0-fold (0.01 log units) below it; measured number inside the range.
By their numbers in this assay, from the lowest: compounds 3, 2, 4 and 1 (each within the scatter of the next).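

In this assay the exchange of diethylamino for dimethylamino on a saturated chain carbon bound to an amide-type nitrogen in a ring stays within the scatter (a 1.1-fold higher number from compound 3 to compound 4 (0.04 log units; within the scatter)). With dimethylamino held constant, chloro on the aromatic carbon also stays within the scatter against fluoro (a 1.0-fold higher number from compound 2 to compound 4 (0.01 log units; within the scatter)) and against methyl (a 1.1-fold lower number from compound 1 to compound 4 (0.03 log units; within the scatter)). No measured evidence bears on these results.

Open, on these data alone, is whether piperidine or morpholine in place of dimethylamino, or a nitrile on the aromatic carbon, would also stay within the scatter.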